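A few compounds are considered here, and "the series" means these few. Any claim that something is new, unique, unknown or untested is made for them only; others in the source may bear on it.

Within the data shown here, compound 2 `CC(C)(C)c1ccc(C(=O)N2CCC3(CC2)C(=O)N(CC(=O)NCN)CN3c2ccccc2)cc1` is the only member of this small set for which a number exists in an assay on HEK293 cells for displacement of a labelled ligand from NPC1-like intracellular cholesterol transporter 1 (Homo sapiens); on this read-out lower numbers stand for stronger inhibition and higher numbers for weaker inhibition: in this assay compound 2 gives 26500 nM. Among the measured compounds shown here, for compound 1 `CC(C)(C)OC(=O)NCCCCNC(=O)CN1CN(c2ccccc2)C2(CCN(C(=O)c3ccc(C(C)(C)C)cc3)CC2)C1=O`, which carries a longer chain ending in a tert-butoxycarbonyl-protected amine, the entry in this assay reads "not determined" (no result reported), so the set offers no comparison between two measured compounds and no measured step to lean on.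

Compound 3 `CC(C)(C)OC(=O)NCCCCCNC(=O)CN1CN(c2ccccc2)C2(CCN(C(=O)c3ccc(C(C)(C)C)cc3)CC2)C1=O` is the untested compound. It differs from compound 2 by 4-((tert-butoxycarbonyl)amino)butyl in place of amino on a saturated chain carbon bound to an amide-type nitrogen. For the measured compounds named here, with no measured step of this kind at hand, the size of the change can only be guessed from the starting point. Given that compound 2 sits at 26500 nM, the step expected in this assay from compound 2 to compound 3, a 1.8-fold lower number from compound 2 to compound 3 (0.25 log units; within the scatter), is a modest one toward stronger inhibition, not far beyond the scatter. Compound 3 is therefore estimated at 15000 nM, with a range from 4000 nM to 50000 nM.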

Compound 3, half-maximal inhibitory concentration: 13700 nM
Compound 3: the middle estimate sits 1.1-fold (0.04 log units) above what was measured; low and high end bracket the measured number.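

Among these compounds, compound 3 provides the first measured step at this position: in this assay, 4-((tert-butoxycarbonyl)amino)butyl in place of amino on a saturated chain carbon bound to an amide-type nitrogen gives a 1.9-fold lower number from compound 2 to compound 3 (0.29 log units; within the scatter). A group of 12 heavy atoms thus stands where a single nitrogen stood, and the read-out does not separate the two compounds beyond the scatter. Nothing available here accounts for this result.

As far as these compounds go, it remains open whether a free amine at the end of the butyl chain, in place of the tert-butoxycarbonyl-protected amine, would shift the number beyond the scatter. The same question stands for a carboxylic acid at that chain end and for a longer chain at this position.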